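A Fluorinated Benzoate in Place of a Succinate Tail

A few compounds are considered here, and "the series" means these few. Any claim that something is new, unique, unknown or untested is made for them only; others in the source may bear on it.

Of the compounds shown here, two built on the same shared core have been measured in a functional assay on MCF7 cells (Homo sapiens) for antiproliferative activity, read by MTT assay, with a stated time of 72 h; on this read-out higher numbers stand for weaker inhibition and lower numbers for stronger inhibition. Compound 1 `CC1=CC[C@H]2[C@H](CC[C@]2(C)O)C(C)(C)[C@@H]1CC[C@H]1[C@]2(C)CC[C@H](OC(=O)CCC(=O)O)C(C)(C)O[C@H]2CC[C@@]1(C)O` gives > 50000 nM in this assay, a value that is a limit of the measurement rather than a number. Compound 2 `CC1=CC[C@H]2[C@@H]1CC=C(C)[C@@H](CC[C@H]1[C@]3(C)CC[C@H](OCc4ccccc4)C(C)(C)O[C@H]3CC[C@@]1(C)O)C2(C)C` also gives > 50000 nM in this assay, again only a limit. Among the compounds with values here, compound 1 therefore stands at the edge of what the measurement can report, and the limit of > 50000 nM in this assay, at which 2 of the 2 values shown sit, describes the same situation for both measured compounds, so no step between them can be sized.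

Compound 3 `CC1=CC[C@H]2[C@H](CC[C@]2(C)O)C(C)(C)[C@@H]1CC[C@H]1[C@]2(C)CC[C@H](OC(=O)c3ccc(C(F)(F)F)c(F)c3)C(C)(C)O[C@H]2CC[C@@]1(C)O` is the unmeasured partner of compound 1. The change is 3-fluoro-4-(trifluoromethyl)phenyl in place of 2-carboxyethyl on a carbonyl carbon. The carboxyl-bearing chain that leaves makes way for an aromatic ring carrying fluorine and a trifluoromethyl group, while the ester carbonyl stays in place.

Within the data shown here, with no measured step available, the expectation rests on compound 1 alone and on the size of the change. For compound 3 the estimate in this assay is 30000 nM, with a range from 8000 nM to 200000 nM, which means an expected step of an at least 1.6-fold lower number from compound 1 to compound 3 (0.22 log units; that floor lies within the scatter), most likely again close to the limit.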

Compound 3, half-maximal inhibitory concentration: > 50000 nM
Compound 3 ended at the assay's limit; the forecaster's own chance of this, stated with the estimate: 60%; middle value at least 1.6-fold (0.22 log units) away from the limit.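

Compound 3 gives > 50000 nM in this assay, which is a limit and not a number. Within the data shown here, compound 1 also stands at a limit, so no step from compound 1 to compound 3 can be read: the limit of > 50000 nM in this assay, at which 3 of the 3 values shown sit. The compounds shown leave open whether any compound on this shared core gives a readable number in this assay.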